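The source may hold more compounds than are shown below. What is called first, only, known or untested is meant among the compounds shown, and "the series" means these compounds.

Series notes. Compound 1 `C#CCO/N=C/c1c(-c2ccc(C)cc2)nc2ccc(Br)cn12` and compound 3 `C#CCO/N=C/c1c(-c2ccc(F)cc2)nc2ccc(Br)cn12` share one core; compound 2 `COc1ccc(Cn2cc(CO/N=C/c3c(-c4ccc(C)cc4)nc4c(C)cccn34)nn2)cc1` and compound 4 `COc1ccc(Cn2cc(CO/N=C/c3c(-c4ccc(F)cc4)nc4c(C)cccn34)nn2)cc1` share another. How the two cores differ is not broken down here. In a functional assay on the whole organism (strain NMRI) with Mus musculus as the target, with a stated time of 0.5 h (a higher number here means that more compound is needed for the effect, a lower number that less compound is needed), compound 1 gives 20 mg/kg, and compound 3 gives 40 mg/kg. The change from compound 1 to compound 3, (fluoro in place of methyl on an aromatic carbon), made a step of a 2.0-fold higher number from compound 1 to compound 3 (0.30 log units; within the scatter). In this assay compound 2 gives 40 mg/kg, level with compound 3 at the digits recorded, and these two stand together as the highest of the three numbers, while compound 1 lies a step away that is within the scatter. Compound 4 carries the same change relative to compound 2, (fluoro in place of methyl on an aromatic carbon); the place is described in the same words for both pairs, so it is taken as the same change. Among the compounds with values here, the expected step in this assay is a 2.0-fold higher number from compound 2 to compound 4 (0.30 log units; within the scatter), set beside the measured one because a 2.0-fold higher number from compound 1 to compound 3 (0.30 log units; within the scatter) is the only reading of this change and it lay within the scatter. Compound 4 is therefore expected to give about 80 mg/kg in this assay, with a likely span from 40 mg/kg to 160 mg/kg. Within the data shown here, only one measured pair supports this expectation, so nothing beyond it is claimed for the series.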

Compound 4, minimum effective dose: 40 mg/kg
Estimate against measurement, compound 4: 2.0-fold (0.30 log units) above, within the range that was stated.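

On the second core, in this assay, the change from 4-methylphenyl to 4-fluorophenyl gives no change at the digits printed from compound 2 to compound 4 (within the scatter), and the readings on the two cores do not differ beyond what repeated measurement would produce: the same change on two cores in this assay, a 2.0-fold higher number (0.30 log units; within the scatter) from compound 1 to compound 3 and no change at the digits printed (within the scatter) from compound 2 to compound 4, 2.0-fold (0.30 log units) apart, within the scatter of two such steps. The two cores therefore give no sign that this change behaves differently from one to the other, and on this limited basis the result is compatible with the change carrying across them. It does not show that the change has a real effect on either core or that its size is constant: both steps lie within the scatter, and two pairs could not reveal a dependence on the core smaller than that scatter.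

The compounds shown leave open whether another group in place of the methyl, such as an amine, a carboxylic acid or a longer chain, would give a step beyond the scatter on either core. They also leave open how the two cores compare with each other, as no pair shown differs in one place only across them.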